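Removing iodo from the core of compound 3: an expectation

A few compounds are considered here, and "the series" means these few. Any claim that something is new, unique, unknown or untested is made for them only; others in the source may bear on it.

Compound 1 `CC1(C)[C@@H](CO)CC[C@@]1(C)Cn1cc(I)c(=O)[nH]c1=O` and compound 2 `CC1(C)[C@@H](CO)CC[C@@]1(C)Cn1ccc(=O)[nH]c1=O` share one core, while compound 3 `O=c1[nH]c(=O)n([C@@H]2CCC[C@H]2CO)cc1I` carries another; the difference between the two cores is not broken down here. In an ADME assay on L1210/0 cells (Mus musculus) for cytotoxicity, with a stated time of 48 h (a higher number here means a weaker inhibitor, a lower number a stronger inhibitor), compound 1 gives only a limit of the assay, > 200000 nM. In this assay compound 2 likewise reaches only the limit, > 200000 nM. In this assay compound 3 also stops at the limit, > 200000 nM. The change from compound 1 to compound 2 is hydrogen in place of iodo on an aromatic carbon, and the step it made, a step that the two limits leave unreadable from compound 1 to compound 2, has no readable size. Compound 4 `O=c1ccn([C@@H]2CCC[C@H]2CO)c(=O)[nH]1` is the unmeasured partner of compound 3, formed by the same kind of change, (hydrogen in place of iodo on an aromatic carbon), whose surroundings differ only in being meta to a group of 7 heavy atoms rather than meta to a large group. Among the compounds with values here, because every value shown sits at the limit of > 200000 nM in this assay, at which 3 of the 3 values shown sit, no measured step is available to size the expectation for compound 4. The step that this expectation implies is estimated at a step that the limit leaves unreadable from compound 3 to compound 4. Compound 4 is expected in this assay to give about 400000 nM, most probably once more only a limit, with a range estimated from 120000 nM to 3000000 nM.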

Compound 4, half-maximal inhibitory concentration: > 200000 nM
Compound 4: no number, only a limit; the forecaster's own chance of this, stated with the estimate: 90%; the middle value lies beyond the limit too.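

No step can be read from compound 3 to compound 4, because both compounds stop at a limit of the assay rather than giving a number, as do compound 1 and compound 2 in this assay: the limit of > 200000 nM in this assay, at which 4 of the 4 values shown sit.

The compounds shown leave open whether hydrogen in place of iodo changes the result in this assay at all, and by how much on either core.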